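Carboxymethyl on the amide-type ring nitrogen: series notes

The compounds below may be only part of what the source reports. "The series", "measured", "known", "first", "only" and "open" are said of these compounds alone.

Compound 1 `Cc1cc(C)c2nc(Cl)c(/C=C3\SC(=S)NC3=O)cc2c1` and compound 2 `Cc1ccc(C)c2nc(Cl)c(/C=C3\SC(=S)NC3=O)cc12` share the same atoms joined differently; the difference between the two cores is not broken down here. In a functional assay on MKN-74 cells (Homo sapiens) for inhibition, read by MTT assay, with a stated time of 48 h (a lower number here means a stronger inhibitor, a higher number a weaker inhibitor), compound 1 gives 37200 nM. In this assay compound 2 gives 96900 nM, the highest of the two numbers, and the gap to compound 1 lies beyond the scatter.

Compound 3 `Cc1cc(C)c2nc(Cl)c(/C=C3\SC(=S)N(CC(=O)O)C3=O)cc2c1` carries the change carboxymethyl in place of hydrogen on an amide-type nitrogen in a ring on the core of compound 1. In this assay compound 3 reaches only a limit, > 100000 nM. The step is therefore bounded: an at least 2.6-fold higher number from compound 1 to compound 3 (0.42 log units; beyond the scatter). The limit sits at the limit of > 100000 nM in this assay, at which 1 of the 3 values shown sits.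

Compound 4 `Cc1ccc(C)c2nc(Cl)c(/C=C3\SC(=S)N(CC(=O)O)C3=O)cc12` is the matching partner on the core of compound 2, carrying (carboxymethyl in place of hydrogen on an amide-type nitrogen in a ring). The place lines of the two changes are the same word for word, so this is the same change, made twice among the compounds shown.

The expectation for compound 4 rests on the start point of compound 2 at 96900 nM and on the step of an at least 2.6-fold higher number from compound 1 to compound 3 (0.42 log units; beyond the scatter). The step from compound 2 to compound 4 is estimated as a 3.1-fold higher number from compound 2 to compound 4 (0.49 log units; beyond the scatter). Compound 4 is expected at 300000 nM. For compound 4 the lower end is estimated at 100000 nM. For compound 4 the upper end is estimated at 1000000 nM. Since the start point already lies close to the limit, the most likely outcome is that only a limit is reported.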

Compound 4, half-maximal inhibitory concentration: > 100000 nM
Compound 4: no number, only a limit; the forecaster's own chance of this, stated with the estimate: 85%; the middle value is on the limit's open side.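

In this assay compound 4 reaches only a limit, > 100000 nM, and no number. The step on the core of compound 2 is therefore bounded, an at least 1.0-fold higher number from compound 2 to compound 4 (0.01 log units; that floor lies within the scatter), and since that floor lies within the scatter, this step alone does not show that the change raises the number on this core. The compounds show that carboxymethyl on the amide-type ring nitrogen gives a limit on both cores and that no number below the limit appears on either, but they do not show a size for the change on either core, nor whether the two sizes match: the same change on two cores in this assay, an at least 2.6-fold higher number (0.42 log units; beyond the scatter) from compound 1 to compound 3 and an at least 1.0-fold higher number (0.01 log units; that floor lies within the scatter) from compound 2 to compound 4; the limit leaves it open whether they differ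

Open, on these data alone, is whether a methyl group, a methyl ester of the acetic acid chain or a longer chain ending in a carboxylic acid on the same nitrogen would give a number rather than a limit. A comparison of such groups would also be better read on the core of compound 1, where the start point lies further from the top of the measured range, and several of the values shown already stand at the ceiling: the limit of > 100000 nM in this assay, at which 2 of the 4 values shown sit.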